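Ring-nitrogen substituents in the shared core

The source may report more compounds than this note shows. Statements on the series, on what has been measured and on what is new or still open speak of the compounds shown alone.

Three compounds share one core and differ only on the amine nitrogen in the ring. In an assay on CHO cells for displacement of a labelled ligand from Substance-P receptor (Homo sapiens) (a lower number here means a stronger inhibitor, a higher number a weaker inhibitor), compound 1 `CCC(=O)N1C[C@@H](O[C@H](C)c2cc(C(F)(F)F)cc(C(F)(F)F)c2)[C@H](c2ccc(F)cc2)C1` gives 0.09 nM, compound 2 `CC(C)C(=O)N1C[C@@H](O[C@H](C)c2cc(C(F)(F)F)cc(C(F)(F)F)c2)[C@H](c2ccc(F)cc2)C1` gives 0.15 nM, and compound 3 `CC(C)NC(=O)N1C[C@@H](O[C@H](C)c2cc(C(F)(F)F)cc(C(F)(F)F)c2)[C@H](c2ccc(F)cc2)C1` gives 0.06 nM. Compound 3 holds the lowest of the three numbers: the step of a 1.5-fold lower number from compound 1 to compound 3 (0.18 log units; within the scatter) is within the scatter, while the step of a 2.5-fold lower number from compound 2 to compound 3 (0.40 log units; beyond the scatter) is modest. The step of a 1.7-fold higher number from compound 1 to compound 2 (0.22 log units; within the scatter) likewise shows that changes at this position moved this assay little. Compound 4 `CC1=C(N2C[C@@H](O[C@H](C)c3cc(C(F)(F)F)cc(C(F)(F)F)c3)[C@H](c3ccc(F)cc3)C2)CCC1=O` carries 2-methyl-3-oxocyclopent-1-en-1-yl in place of isopropylcarbamoyl on an amine nitrogen in a ring, which removes the carbonyl from the nitrogen, so the measured steps bear on it only loosely. A step of about a 3.3-fold higher number from compound 3 to compound 4 (0.52 log units; beyond the scatter) toward a higher number is expected. Compound 4 is estimated at 0.2 nM, range 0.05 nM to 0.8 nM.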

Compound 4, half-maximal inhibitory concentration: 0.13 nM
Compound 4: middle estimate off by 1.5-fold (0.19 log units), on the high side, and the stated range covers the measured number.
By their numbers in this assay, from the lowest: compounds 3, 1, 4 and 2 (each within the scatter of the next, the first and the last beyond it).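

Putting 2-methyl-3-oxocyclopent-1-en-1-yl on the amine nitrogen in a ring keeps this assay close to the propanoyl and isopropylcarbonyl compounds: a 1.4-fold higher number from compound 1 to compound 4 (0.16 log units; within the scatter) and a 1.2-fold lower number from compound 2 to compound 4 (0.06 log units; within the scatter). Only a 2.2-fold higher number from compound 3 to compound 4 (0.34 log units; beyond the scatter) goes beyond the scatter, and it is modest, so among these compounds a carbonyl bound directly to this nitrogen is not needed for a number of this size. No supporting measurement explains these steps. Still open, as far as these compounds go, is whether a longer chain in place of the methyl on this ring, or an amine in place of its oxo group, would hold the number.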